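This account rests on a few compounds, and the source may have more. Where it says the series, first, only, none or still open, it means among the compounds named here.

Measured compounds:
- Compound 1, `Oc1ccc(-c2cc(-c3ccccc3)nc(-c3ccccc3Cl)c2)cc1`: in an ADME assay on HEK293 cells (Homo sapiens) for cytotoxicity, read by CCK-8 assay and cell counting, with a stated time of 2 days (a lower number here means a stronger inhibitor, a higher number a weaker inhibitor), compound 1 gives 3930 nM
- Compound 2, `Oc1cccc(-c2cc(-c3ccsc3)nc(-c3ccccc3Cl)c2)c1`: in this assay compound 2 gives 2720 nM
- Compound 3, `Oc1ccc(-c2cc(-c3ccco3)nc(-c3ccccc3Cl)c2)cc1`: in this assay compound 3 gives 4310 nM

Compound 3 carries the highest of the three numbers, but every gap separating it from the others lies within the scatter, so the three compounds are not distinguishable here. The step to the unmeasured compound 4, `Oc1ccc(-c2cc(-c3ccsc3)nc(-c3ccccc3Cl)c2)cc1`, is thiophen-3-yl in place of furan-2-yl on an aromatic carbon. Within the data shown here, the one measured step that touches the same position, a 1.1-fold higher number from compound 1 to compound 3 (0.04 log units; within the scatter), stayed within the scatter. Compound 2 also carries thiophen-3-yl, and the values of compound 2 and compound 3 sit within the scatter of each other, though no single-change comparison exists between them. Nothing measured therefore points to a shift beyond the scatter when thiophen-3-yl replaces furan-2-yl. The step from compound 3 to compound 4 is expected to be a 1.2-fold lower number from compound 3 to compound 4 (0.09 log units; within the scatter). Compound 4 is estimated at 3500 nM, with a likely range from 1700 nM to 7500 nM.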

Compound 4, half-maximal inhibitory concentration: 5930 nM
Compound 4: the middle estimate sits 1.7-fold (0.23 log units) below what was measured, and the stated range covers the measured number.
By their numbers in this assay, from the lowest: compounds 2, 1, 3 and 4 (each within the scatter of the next, the first and the last beyond it).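

In this assay, the group next to the ring nitrogen has now been varied among phenyl, furan-2-yl and thiophen-3-yl with no clear effect: thiophen-3-yl in place of furan-2-yl gives a 1.4-fold higher number from compound 3 to compound 4 (0.14 log units; within the scatter), and thiophen-3-yl in place of phenyl gives a 1.5-fold higher number from compound 1 to compound 4 (0.18 log units; within the scatter). Among these compounds, the only single change here that passes the scatter lies at the other aryl group, where 4-hydroxyphenyl in place of 3-hydroxyphenyl gives a 2.2-fold higher number from compound 2 to compound 4 (0.34 log units; beyond the scatter), a modest step. No supporting evidence is available to explain this step.

Every group shown at the position next to the ring nitrogen is an aromatic ring, so the effect of an amine or a longer alkyl chain there remains open. From the compounds shown here alone, the hydroxyl comparison also rests on a single pair, both members carrying thiophen-3-yl, so it remains open whether the step recurs with phenyl or furan-2-yl.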